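The compounds below may be only part of what the source reports. "The series", "measured", "known", "first", "only" and "open" are said of these compounds alone.

Measured compounds:
- compound 1 `CO[C@@H]1[C@@H](OC)[C@H](c2ccccc2)O[C@@H]2CO[C@@H](c3ccc(C)cc3)O[C@@H]12`: "not determined" (no result reported)
- compound 2 `CO[C@@H]1[C@@H](OC)[C@H](c2ccccc2)O[C@@H]2CO[C@@H](c3ccc(C(F)(F)F)cc3)O[C@@H]12`: >= 16 ug/mL

Compound 1 has no reported result in a functional assay on HEL cells (Homo sapiens) for cytotoxicity (a higher number here means that more compound is tolerated, a lower number that less compound is tolerated), so it gives no foothold. In this assay compound 2 gives >= 16 ug/mL, which is a limit of the assay rather than a single number. Compound 2 therefore stands at the limit of >= 16 ug/mL in this assay, at which 1 of the 2 values shown sits, and nothing places it more precisely than that.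

Compound 3 `CO[C@@H]1[C@@H](OC)[C@H](c2ccccc2)O[C@@H]2CO[C@@H](c3ccc(-c4ccccc4)cc3)O[C@@H]12` differs from compound 2 in one place: phenyl in place of trifluoromethyl on an aromatic carbon. For the measured compounds named here, no pair of measured compounds differing in a single place is available, so there is no measured step to lean on, and the direction of the change for compound 3 stays open. A step of a number no higher from compound 2 to compound 3 (the limit leaves the size open) is expected, which would not go beyond the usual scatter. Compound 3 is expected to give about 16 ug/mL in this assay, with a range from 8 ug/mL to 32 ug/mL, and a limit rather than a number is again quite likely.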

Compound 3, minimum cytotoxic concentration: >= 16 ug/mL
Compound 3 was reported as a limit; the forecaster's own chance of this, stated with the estimate: 60%; the middle value sits exactly at the limit.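

No step can be read from compound 2 to compound 3, since the results of both in this assay are limits and not single numbers: the limit of >= 16 ug/mL in this assay, at which 2 of the 3 values shown sit. The compounds shown leave open where the actual tolerated concentration of each lies, and whether swapping trifluoromethyl for phenyl changes it at all.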